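Swapping the aryl group on the carbonyl of compound 2

This account rests on a few compounds, and the source may have more. Where it says the series, first, only, none or still open, it means among the compounds named here.

Among the compounds with values here, compound 2 `O=C(/C=C/c1ccc2c(c1)B(O)OC2)c1ccc(I)cc1` is the only compound here with a number in a functional assay on MDA-MB-231 cells (Homo sapiens) for cytotoxicity, read by MTT assay, with a stated time of 48 h; on this read-out lower numbers stand for stronger inhibition and higher numbers for weaker inhibition: compound 2 gives 14900 nM. Compound 1 `Cn1cccc1C(=O)/C=C/c1ccc2c(c1)B(O)OC2` sits at a limit of the assay, > 100000 nM (the limit of > 100000 nM in this assay, at which 1 of the 2 values shown sits). Within the data shown here, the one measured step is an at least 6.7-fold lower number from compound 1 to compound 2 (0.82 log units; beyond the scatter). Compound 3 `Cc1cccc(C(=O)/C=C/c2ccc3c(c2)B(O)OC3)c1` differs from compound 2 in this way: 3-methylphenyl in place of 4-iodophenyl on a carbonyl carbon. Among the measured compounds shown here, no measured step swaps one phenyl for another, so the size of this change is uncertain, and a step within the scatter or a modest weakening is expected, a 1.7-fold higher number from compound 2 to compound 3 (0.22 log units; within the scatter). Compound 3 is therefore estimated at 25000 nM, between 8000 nM and 80000 nM.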

Compound 3, half-maximal inhibitory concentration: 4500 nM
Estimate against measurement, compound 3: 5.6-fold (0.74 log units) above; measured number below the stated range.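

Even between two phenyl groups, the group on this carbonyl carbon changes the result in this assay: 3-methylphenyl in place of 4-iodophenyl gives a 3.3-fold lower number from compound 2 to compound 3 (0.52 log units; beyond the scatter) and so counts as a real difference. Replacing 1-methyl-1H-pyrrol-2-yl with 3-methylphenyl gives an at least 22-fold lower number from compound 1 to compound 3 (1.34 log units; beyond the scatter) as a further step on the same carbon. That step is only a bound, since compound 1 stands at a limit: the limit of > 100000 nM in this assay, at which 1 of the 3 values shown sits.

Going by these compounds, the swap changes both the substituent and its ring position, so the contribution of each stays open. On these data alone, a 4-methylphenyl or 3-iodophenyl group would separate them, and an amine on the phenyl ring remains untested here.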